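Swapping chloro for methyl in a weakly cytotoxic series

The source may report more compounds than this note shows. Statements on the series, on what has been measured and on what is new or still open speak of the compounds shown alone.

Compound 1 `Cc1ccc(Cn2c(N)nc3cc(Cl)c(Cl)cc32)cc1`: 40000 nM
Compound 2 `Clc1ccc(Cn2c(Br)nc3cc(Cl)c(Cl)cc32)cc1`: > 100000 nM

In a functional assay on CEM-SS cells (Homo sapiens) for cytotoxicity (on this read-out lower numbers stand for stronger inhibition and higher numbers for weaker inhibition), compound 2 yields no number, only a limit of > 100000 nM as its reading. Compound 3 `Cc1ccc(Cn2c(Br)nc3cc(Cl)c(Cl)cc32)cc1` has methyl in place of chloro on an aromatic carbon of compound 2, para to a large group methyl in place of chloro on an aromatic carbon and is still unmeasured. For the measured compounds named here, no measured pair shows this exchange on its own. Compound 1 carries the same methyl alongside a different group elsewhere and reads 40000 nM in this assay so a weak number remains plausible. No step beyond the usual scatter is expected, and any shift would most likely run toward lower numbers. The expected change is an at least 1.4-fold lower number from compound 2 to compound 3 (0.15 log units; that floor lies within the scatter) as estimated. For compound 3 the expected value is 70000 nM with an estimated range of 30000 nM to 100000 nM in this assay as the reading.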

Compound 3, half-maximal inhibitory concentration: > 100000 nM
Compound 3: a limit, no number (the forecaster's own chance of this, stated with the estimate: 55%); middle value at least 1.4-fold (0.15 log units) away from the limit.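

In this assay, methyl in place of chloro on an aromatic carbon, para to a large group, yields no number: compound 3 gives only a limit, > 100000 nM. For the compounds shown here, the step between compound 2 and compound 3 cannot be read, because both stop at the same limit: the limit of > 100000 nM in this assay, at which 2 of the 3 values shown sit. With the methyl held fixed, the one readable comparison concerns the other site, where bromo in place of amino on an aromatic carbon gives an at least 2.5-fold higher number from compound 1 to compound 3 (0.39 log units; beyond the scatter).

From the compounds shown here alone, whether methyl and chloro differ at all at this position stays open, as does how far compound 2 and compound 3 lie past the limit. Going by these compounds, it is also open whether a methoxy group at this position, or a dimethylamino group in place of the bromo, would bring a reading back inside the measurable range.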